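A few compounds are considered here, and "the series" means these few. Any claim that something is new, unique, unknown or untested is made for them only; others in the source may bear on it.

Three compounds have numbers in a functional assay on SK-MEL-147 cells (Homo sapiens) for cytotoxicity, read by MTT assay, with a stated time of 24 h; on this read-out higher numbers stand for an effect only at larger amounts of compound and lower numbers for an effect already at smaller amounts:

Compound 1 `CCCCC#Cc1cc(C(=O)OCC)nc2ccc(OC)cc12`: 7200 nM
Compound 2 `CCOC(=O)c1cc([Se]Cc2ccccc2)c2cc(Cl)ccc2n1`: 84500 nM
Compound 3 `COc1ccc2nc(-c3c(C)cccc3C)cc([Se]c3ccccc3)c2c1`: 37300 nM

Compound 1 stands lowest of the three, and its gaps to compound 3 and to compound 2 both lie beyond the scatter. Compound 4 `CCOC(=O)c1cc([Se]c2ccc(F)cc2)c2cc(OC)ccc2n1` has not yet been measured in this assay. It differs from compound 1 in one place: a group of 8 heavy atoms (6 carbon, 1 fluorine, 1 selenium; one six-membered aromatic ring of carbon only) in place of a group of 6 heavy atoms (6 carbon; no ring), on an aromatic carbon. Going by the values given here, no measured pair shows this exact change, so its size must be judged from the wider set. Both compounds that carry selenium give the higher numbers, compound 3 with 37300 nM and compound 2 with 84500 nM, though neither shares the rest of compound 1. An upward step beyond the scatter is therefore expected, with the estimated step of a 4.2-fold higher number from compound 1 to compound 4 (0.62 log units; beyond the scatter). For compound 4 the expected value is 30000 nM, within a range from 10000 nM to 90000 nM.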

Compound 4, half-maximal effective concentration: > 150000 nM
Compound 4 ended at the assay's limit; the forecaster's own chance of this, stated with the estimate: 10%; at least 5.0-fold (0.69 log units) between middle value and limit.
By their numbers in this assay, from the lowest: compound 1; then compound 3; then compound 2. At a limit, above all of these: compound 4.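

In this assay, putting the group of selenium and a fluorine-bearing six-membered aromatic ring in place of hex-1-yn-1-yl, on the aromatic carbon opposite the ring nitrogen, gives an at least 20-fold higher number from compound 1 to compound 4 (1.31 log units; beyond the scatter). Going by these compounds alone, this is the first comparison at this position in which only one place differs, and here hex-1-yn-1-yl goes with the lower number. Compound 4 stands at a limit of the assay, so the step has no upper size: the limit of > 150000 nM in this assay, at which 1 of the 4 values shown sits.

Whether selenium, fluorine or the aromatic ring accounts for the step stays open. So does how a longer alkynyl chain or an amine would read at this position.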